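Pyridinone series: removing the methanesulfonamido group

The source may hold more compounds than are shown below. What is called first, only, known or untested is meant among the compounds shown, and "the series" means these compounds.

Compound 2 `CCCCc1ccc(CNS(C)(=O)=O)c(=O)n1Cc1ccc(-c2ccccc2-c2nn[nH]n2)cc1` gives the lowest number among the two compounds measured in a functional assay (aorta) for antagonist activity, with Oryctolagus cuniculus as the target (a lower number here means a stronger inhibitor, a higher number a weaker inhibitor), at 2 nM. Its nearest neighbour, compound 1 `CCCCc1ccc(CNC(=O)NC2CCCCC2)c(=O)n1Cc1ccc(-c2ccccc2-c2nn[nH]n2)cc1`, gives 90 nM in this assay. Going by the values given here, the only measured step, a 45-fold lower number from compound 1 to compound 2 (1.65 log units; beyond the scatter), shows that the group carried on this amine nitrogen moves the read-out by a large amount.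

Compound 3 `CCCCc1ccc(C)c(=O)n1Cc1ccc(-c2ccccc2-c2nn[nH]n2)cc1` is not yet measured. It differs from compound 2 by hydrogen in place of methanesulfonamido on a saturated chain carbon bound to an aromatic carbon. This removes the group altogether rather than exchanging it, so the step from compound 1 to compound 2 bears on it only as evidence that this position is sensitive; it does not show whether the bare methyl sits nearer the number of compound 1 or that of compound 2. Among the compounds with values here, no other measured pair speaks to a substituent-free chain carbon at this place.

Given that sensitivity, a step beyond the scatter toward a higher number is expected for compound 3, of roughly a 10-fold higher number from compound 2 to compound 3 (1.00 log units; beyond the scatter). The estimate for compound 3 in this assay is 20 nM, with a range from 4 nM to 100 nM.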

Compound 3, half-maximal inhibitory concentration: 7 nM
Compound 3: the middle estimate sits 2.9-fold (0.46 log units) above what was measured; the range from low to high includes it.
By their numbers in this assay, from the lowest: compound 2; then compound 3; then compound 1.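

In this assay, taking the methanesulfonamido group off leaves only a modest loss, a 3.5-fold higher number from compound 2 to compound 3 (0.54 log units; beyond the scatter), so the bare methyl already holds most of the inhibition and this saturated chain carbon bound to an aromatic carbon needs no substituent for a low number. Measured against that bare methyl, the two groups pull in opposite directions and by unequal amounts: a 13-fold lower number from compound 1 to compound 3 (1.11 log units; beyond the scatter) is the larger step, which places most of the earlier gap between the two substituted compounds in the penalty carried by (cyclohexylcarbamoyl)amino rather than in any gain from methanesulfonamido. No measurement at hand gives a cause for either step.

The compounds shown leave open whether an amine, a hydroxyl or a carboxylic acid on this carbon would sit nearer compound 2 or compound 3, and whether an acetamide would keep the small gain seen with methanesulfonamido. Also open, on these data alone, is whether a longer chain in place of the bare methyl would raise the number, or whether a plain alkyl extension is tolerated where (cyclohexylcarbamoyl)amino is not.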